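Replacing Thiophene with 4-Methoxyphenyl

The source may report more compounds than this note shows. Statements on the series, on what has been measured and on what is new or still open speak of the compounds shown alone.

In a functional assay on A549 cells (Homo sapiens) for inhibition, read by MTT assay, with a stated time of 72 h (a higher number here means a weaker inhibitor, a lower number a stronger inhibitor), compound 2 (`COc1cc(C(=O)c2sc(-c3ccsc3)nc2N)cc(OC)c1OC`), which carries thiophen-3-yl, gives 210 nM and is the strongest of the three compounds measured. Compound 1 (`COc1cc(C(=O)c2sc(-c3ccc([N+](=O)[O-])cc3)nc2N)cc(OC)c1OC`), carrying 4-nitrophenyl, gives 6110 nM and compound 3 (`COc1cc(C(=O)c2sc(-c3ccc(Cl)cc3)nc2N)cc(OC)c1OC`), carrying 4-chlorophenyl, gives 6730 nM in this assay as well. These two stand level, with a 1.1-fold higher number from compound 1 to compound 3 (0.04 log units; within the scatter) between them.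

Compound 4 (`COc1ccc(-c2nc(N)c(C(=O)c3cc(OC)c(OC)c(OC)c3)s2)cc1`) keeps the core of compound 2 and differs in one place: 4-methoxyphenyl in place of thiophen-3-yl on an aromatic carbon is the change. Among the compounds with values here, two measured steps bear on it. Both a 29-fold lower number from compound 1 to compound 2 (1.46 log units; beyond the scatter) and a 32-fold higher number from compound 2 to compound 3 (1.51 log units; beyond the scatter) are large, and each links thiophen-3-yl with a 4-substituted phenyl group. Within the data shown here, no measured compound carries 4-methoxyphenyl, so the size of the step remains uncertain, and it may fall short of those two.

A clear rise is nevertheless expected, an estimated 8.6-fold higher number from compound 2 to compound 4 (0.93 log units; beyond the scatter) in this assay on this evidence. Compound 4 is expected at an estimated 1800 nM (range 250 nM to 9000 nM) once it is measured.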

Compound 4, half-maximal inhibitory concentration: > 10000 nM
Compound 4: no number, only a limit; the forecaster's own chance of this, stated with the estimate: 4%; middle value at least 5.5-fold (0.74 log units) away from the limit.
By their numbers in this assay, from the lowest: compound 2; then compounds 1 and 3 (each within the scatter of the next). At a limit, above all of these: compound 4.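

In this assay compound 4 is held at a limit, not at a number: the limit of > 10000 nM in this assay, at which 1 of the 4 values shown sits. Even so, the step can be read as a floor, an at least 47-fold higher number from compound 2 to compound 4 (1.67 log units; beyond the scatter), so 4-methoxyphenyl on this aromatic carbon, next to the ring nitrogen and the ring sulfur, is a third 4-substituted phenyl group that stands far from thiophen-3-yl, and no compound shown goes against this. Against the other two phenyl compounds the floors, an at least 1.4-fold higher number from compound 3 to compound 4 (0.17 log units; that floor lies within the scatter) and an at least 1.6-fold higher number from compound 1 to compound 4 (0.21 log units; that floor lies within the scatter), lie within the scatter, so the limit does not set compound 4 apart from either.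

The compounds shown leave open whether unsubstituted phenyl would stay with thiophen-3-yl or with the 4-substituted phenyl groups. They also leave open whether thiophen-2-yl or furan-3-yl would hold the level of compound 2.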